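Amide-nitrogen substituent change from compound 2 to compound 3

This account rests on a few compounds, and the source may have more. Where it says the series, first, only, none or still open, it means among the compounds named here.

Going by the values given here, in an ADME assay on the whole organism for pharmacokinetics, with Rattus norvegicus as the target, at a dose of 2 mg/kg by the intravenous route (on this read-out lower numbers stand for slow clearance and higher numbers for fast clearance), compound 1 `CC(C)(O)c1ccc(-c2cnc3c(n2)N(CCC2CCOCC2)C(=O)CN3)cn1` gives 9 mL/min/kg and is the only number. Compound 2 `CC(C)(O)c1ccc(-c2cnc3c(n2)N(CC2CCOCC2)C(=O)CN3)cn1` stands as "not determined" (no result reported) with no result reported, so it offers no starting value. Compound 3 `CO[C@H]1CC[C@H](N2C(=O)CNc3ncc(-c4ccc(C(C)(C)O)nc4)nc32)CC1` is still unmeasured. The change 4-methoxycyclohexyl in place of (oxan-4-yl)methyl on an amide-type nitrogen in a ring puts 4-methoxycyclohexyl in place of (oxan-4-yl)methyl on an amide-type nitrogen in a ring. Among the compounds with values here, no measured step exists for this change. Resting on compound 1 at 9 mL/min/kg alone, no shift beyond the usual scatter of this assay is expected, in either direction. Compound 3 is estimated at 9 mL/min/kg (range 4 mL/min/kg to 20 mL/min/kg).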

Compound 3, clearance: 4.9 mL/min/kg
For compound 3 the middle estimate is 1.8-fold (0.26 log units) above the measured one; the range from low to high includes it.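

In this assay, going by these compounds alone, the step of a 1.8-fold lower number from compound 1 to compound 3 (0.26 log units; within the scatter) gives the first pair of numbers at this position, on an amide-type nitrogen in a ring: 4-methoxycyclohexyl in place of 2-(oxan-4-yl)ethyl stays within the scatter. Compound 2 has no reported number, so the steps from it cannot be read. No measurement shown accounts for this result. Open, going by these compounds, is how an amine or a carboxylic acid in place of the methoxy group on the cyclohexyl ring would read out, and whether the other stereoisomer of compound 3 would stay within the scatter.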